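Swapping one nitro for chloro on the triazole-linked phenyl

The source may hold more compounds than are shown below. What is called first, only, known or untested is meant among the compounds shown, and "the series" means these compounds.

Three compounds share a core and differ only in the aryl group on the triazole nitrogen. Compound 1 `CC(=O)Nc1ccc(-n2nncc2CN2C(=O)C3(C(C#N)=C(N)Oc4c(N)cc5nc6ccccc6nc5c43)c3ccccc32)cc1` carries a 4-acetamidophenyl group; in a functional assay on HepG2 cells (Homo sapiens) for antiproliferative activity, read by MTT assay, with a stated time of 48 h (a higher number here means a weaker inhibitor, a lower number a stronger inhibitor), compound 1 gives > 50000 nM, which is a limit of the assay rather than a number. Compound 2 `COc1ccc(-n2nncc2CN2C(=O)C3(C(C#N)=C(N)Oc4c(N)cc5nc6ccccc6nc5c43)c3ccccc32)cc1` carries a 4-methoxyphenyl group; in this assay compound 2 gives > 50000 nM, again only a limit. For the measured compounds named here, compound 3 `N#CC1=C(N)Oc2c(N)cc3nc4ccccc4nc3c2C12C(=O)N(Cc1cnnn1-c1ccc([N+](=O)[O-])cc1[N+](=O)[O-])c1ccccc12` carries a 2,4-dinitrophenyl group and is the only one with a measured number: in this assay compound 3 gives 18400 nM. The steps of an at least 2.7-fold lower number from compound 1 to compound 3 (0.43 log units; beyond the scatter) and an at least 2.7-fold lower number from compound 2 to compound 3 (0.43 log units; beyond the scatter) show that the dinitrophenyl group is the only one so far that brings the number into the measurable range, because of the limit of > 50000 nM in this assay, at which 2 of the 3 values shown sit.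

Compound 4 `N#CC1=C(N)Oc2c(N)cc3nc4ccccc4nc3c2C12C(=O)N(Cc1cnnn1-c1ccc(Cl)cc1[N+](=O)[O-])c1ccccc12` differs from compound 3 in one place: chloro in place of nitro on an aromatic carbon. Going by the values given here, no measured step covers this exact change. Keeping one nitro group while removing the other lies between compound 3 and the two limit compounds, so compound 4 is expected to show a 1.6-fold higher number from compound 3 to compound 4 (0.21 log units; within the scatter), a somewhat higher number. The estimate for compound 4 in this assay is 30000 nM, within 12000 nM to 60000 nM.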

Compound 4, half-maximal inhibitory concentration: > 50000 nM
Compound 4: no number, only a limit; the forecaster's own chance of this, stated with the estimate: 35%; at least 1.6-fold (0.22 log units) between middle value and limit.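

Until now the 2,4-dinitrophenyl group could only be compared as a whole with other aryl groups, whereas this result singles out one of its two nitro groups, the one para to a large group. Changing that nitro to chloro gives an at least 2.7-fold higher number from compound 3 to compound 4 (0.43 log units; beyond the scatter) in this assay, so the remaining nitro group alone does not bring the number into the measurable range. The steps from compound 1 and from compound 2 to compound 4 cannot be read because both ends of each are limits: the limit of > 50000 nM in this assay, at which 3 of the 4 values shown sit.

As far as these compounds go, the true size of the step to compound 4 stays open, since only its minimum is known. Also open, from the compounds shown here alone, is whether an amine or a carboxylic acid in this place would give a measurable number, and what the other nitro group contributes.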